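Moving the chlorine on the pendant phenyl of compound 1

The source may report more compounds than this note shows. Statements on the series, on what has been measured and on what is new or still open speak of the compounds shown alone.

Compound 1 `CS(=O)(=O)c1ccc(NC(=O)CSc2nnc(N3C(=O)CSC3c3cccc(Cl)c3)s2)cc1` gives 113000 nM in an ADME assay on MT4 cells (Homo sapiens) for cytotoxicity, read by MTT assay, with a stated time of 5 days (on this read-out higher numbers stand for lower toxicity in this test and lower numbers for higher toxicity in this test), the lowest of the two numbers measured, with compound 2 `NS(=O)(=O)c1ccc(NC(=O)CSc2nnc(N3C(=O)CSC3c3cccc(Cl)c3)s2)cc1` at 118000 nM close by. Within the data shown here, the one measured step, a 1.0-fold higher number from compound 1 to compound 2 (0.02 log units; within the scatter), concerns the sulfonyl group and not the chlorophenyl, so it does not bear directly on the change to compound 3 `CS(=O)(=O)c1ccc(NC(=O)CSc2nnc(N3C(=O)CSC3c3ccc(Cl)cc3)s2)cc1`, namely (4-chlorophenyl in place of 3-chlorophenyl on a saturated ring carbon). Among the measured compounds shown here, no measured step therefore sets a direction, and he expects a step of no change at the digits printed from compound 1 to compound 3 (within the scatter), within the scatter. For compound 3 the estimate is 113000 nM, in the range 55000 nM to 230000 nM.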

Compound 3, half-maximal cytotoxic concentration: 116000 nM
The estimate for compound 3 lay 1.0-fold (0.01 log units) below the measured number; the range from low to high includes it.
By their numbers in this assay, from the lowest: compounds 1, 3 and 2 (each within the scatter of the next).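

In this assay the swap to 4-chlorophenyl in place of 3-chlorophenyl on a saturated ring carbon gives a 1.0-fold higher number from compound 1 to compound 3 (0.01 log units; within the scatter) and so the two placements of the chlorine cannot be told apart on this read-out. Among these compounds, this is the first reading at the chlorophenyl, as the earlier compounds differ only at the sulfonyl group. No measurement at hand bears on this result. The compounds shown leave open whether the chlorine itself matters on this phenyl, and whether a methoxy group, an amine or a carboxylic acid in its place would give a number apart from those of compound 1 and compound 3.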